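This account rests on a few compounds, and the source may have more. Where it says the series, first, only, none or still open, it means among the compounds named here.

Three compounds share one core and differ from one another in a single substituent: compound 1 `CNC(=O)c1cc(Oc2ccc(NC(=O)c3cc4cccnc4n(-c4ccc(OC)cc4)c3=O)cc2)ccn1`, compound 2 `CNC(=O)c1cc(Oc2ccc(NC(=O)c3cc4cccnc4n(-c4ccc(Br)cc4F)c3=O)cc2)ccn1` and compound 3 `CNC(=O)c1cc(Oc2ccc(NC(=O)c3cc4cccnc4n(-c4ccc(C(F)(F)F)cc4Cl)c3=O)cc2)ccn1`. In a functional assay on U-87MG ATCC cells for antiproliferative activity against U-87 MG (Homo sapiens), read by MTT assay, with a stated time of 72 h (a higher number here means a weaker inhibitor, a lower number a stronger inhibitor), compound 1 gives "not determined" (no result reported) and compound 2 gives "not determined" (no result reported). In this assay, among the measured compounds shown here, compound 3 gives 19800 nM, the only number reported, so compound 3 stands alone and nothing can be compared with it. Compound 4 `CCCNC(=O)c1cc(Oc2ccc(NC(=O)c3cc4cccnc4n(-c4ccc(C(F)(F)F)cc4Cl)c3=O)cc2)ccn1` differs from compound 3 by ethyl in place of hydrogen on a saturated chain carbon bound to an amide-type nitrogen. For the measured compounds named here, no measured pair shows what such a change does in this assay, so neither size nor direction of a step can be read from the data. In this assay the step is expected to be small, a 1.0-fold higher number from compound 3 to compound 4 (0.00 log units; within the scatter), within the usual scatter. Compound 4 is therefore estimated at 20000 nM, with a range from 6000 nM to 60000 nM.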

Compound 4, half-maximal inhibitory concentration: 10900 nM
Estimate against measurement, compound 4: 1.8-fold (0.26 log units) above; the measured number falls inside the stated range.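

In this assay, among the compounds shown here, the first measured pair at this place reads a 1.8-fold lower number from compound 3 to compound 4 (0.26 log units; within the scatter), so going from methylcarbamoyl to propylcarbamoyl leaves the two compounds indistinguishable. An ethyl on the saturated chain carbon bound to the amide-type nitrogen is thus accommodated with no change that can be told from scatter, though this rests on a single pair. Nothing given here offers an explanation for this result. Going by these compounds, what a longer chain, or a chain ending in an amine or a carboxylic acid, would do at this place stays open.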